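Swapping the acid of compound 2 for an aminoanilide

The compounds below may be only part of what the source reports. "The series", "measured", "known", "first", "only" and "open" are said of these compounds alone.

Compound 2 `O=C(O)c1ccc(NCc2nc(-c3ccccc3)nn2-c2ccccc2)cc1` sits at the bottom of the three measured values: in an assay on Sf9 cells for inhibition of protein deacetylase HDAC6 (Homo sapiens), read by fluorescence, with a stated time of 40 min, tested at 100 nM (a higher number here means more inhibition at the concentration tested (going by the name of the read-out), a lower number less inhibition), compound 2 gives -0.4%, while compound 1 `Cc1ccc(-c2nc(CNc3ccc(C(=O)NO)cc3)n(-c3ccccc3)n2)o1` gives 60.7% and compound 3 `O=C(NO)c1ccc(NCc2nc(-c3ccccc3Cl)nn2-c2ccccc2)cc1` gives 75%. Compound 4 `Nc1ccccc1NC(=O)c1ccc(NCc2nc(-c3ccccc3)nn2-c2ccccc2)cc1` differs from compound 2 only at the carbonyl carbon ((2-aminophenyl)amino in place of hydroxy on a carbonyl carbon). Among the compounds with values here, the one measured step, a number 14.3 percentage points higher from compound 1 to compound 3 (beyond the scatter), alters a different part of the shared core, so no measured step bears directly on this change; the values show only that the two hydroxamic acids give higher numbers in this assay and the acid a lower one. An upward step is therefore expected for compound 4, yet a limited one, estimated as a number 12.4 percentage points higher from compound 2 to compound 4 (beyond the scatter). Compound 4 is expected to give about 12%, between -5% and 40%.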

Compound 4, a percentage reported as inhibition, at one concentration (the size of the read-out at that concentration, not a potency): 5%
Estimate against measurement, compound 4: 7 percentage points above; the measured number falls inside the stated range.
By their numbers in this assay, from the lowest: compounds 2 and 4 (each within the scatter of the next); then compound 1; then compound 3.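

Within the data shown here, this is the first measured change at this position: on the carbonyl carbon, (2-aminophenyl)amino in place of hydroxy gives a number 5.4 percentage points higher from compound 2 to compound 4 (within the scatter). In this assay, compound 2 and compound 4 therefore cannot be told apart, so replacing hydroxy with this larger group, which brings an added aromatic ring, makes no clear difference on this core. Nothing available explains this result.

Going by these compounds, it remains open how methoxy or hydroxyamino on the same carbonyl carbon would read on the core of compound 2.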